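From compound 3 to compound 4: changing the amide substituent

The source may report more compounds than this note shows. Statements on the series, on what has been measured and on what is new or still open speak of the compounds shown alone.

Measured in a functional assay on MCF7 cells (Homo sapiens) for antiproliferative activity, read by MTT assay, with a stated time of 24 h; on this read-out lower numbers stand for stronger inhibition and higher numbers for weaker inhibition:
Compound 1 `CCn1c(C(=O)N[C@@H](C)C(=O)OC)ccc1C(CC)(CC)c1ccc(OCS(=O)(=O)c2ccccc2)c(C)c1`: 43700 nM
Compound 2 `CCn1c(C(=O)N[C@H](C)C(=O)OC)ccc1C(CC)(CC)c1ccc(OCS(=O)(=O)c2ccccc2)c(C)c1`: > 50000 nM (a limit of the assay, not a number)
Compound 3 `CCn1c(C(=O)NC(C)(C)CO)ccc1C(CC)(CC)c1ccc(OCS(=O)(=O)c2ccccc2)c(C)c1`: 20700 nM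

Among these three, compound 3 has the lowest number, and compound 1 is its nearest neighbour. Compound 4 `CCn1c(C(=O)N[C@H](CO)CCO)ccc1C(CC)(CC)c1ccc(OCS(=O)(=O)c2ccccc2)c(C)c1` keeps the shared core and alters only the group on an amide-type nitrogen: 3-hydroxy-1-(hydroxymethyl)propyl in place of 1-(hydroxymethyl)-1-methylethyl on an amide-type nitrogen. In words, 3-hydroxy-1-(hydroxymethyl)propyl replaces 1-(hydroxymethyl)-1-methylethyl.

Two measured steps changed the group at this same place: a 2.1-fold lower number from compound 1 to compound 3 (0.32 log units; beyond the scatter) and an at least 2.4-fold lower number from compound 2 to compound 3 (0.38 log units; beyond the scatter). Both are modest and beyond the scatter, and the second is only a minimum, set by the limit of > 50000 nM in this assay, at which 1 of the 3 values shown sits. A third step, an at least 1.1-fold higher number from compound 1 to compound 2 (0.05 log units; that floor lies within the scatter), involves only (the fact that compounds 1 and 2 differ only in the configuration as drawn), and its floor lies within the scatter. That step gives little guidance on the defined stereocentre in the entering group.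

Both groups in the new change contain hydroxymethyl, unlike the 1-(methoxycarbonyl)ethyl group that left in a 2.1-fold lower number from compound 1 to compound 3 (0.32 log units; beyond the scatter), so a smaller step than that one is expected here. The expected step is a 1.4-fold higher number from compound 3 to compound 4 (0.13 log units; within the scatter), which would not clearly exceed the scatter. For compound 4, the estimated value is 28000 nM, with an expected range of 12000 nM to 50000 nM.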

Compound 4, half-maximal inhibitory concentration: 28500 nM
Compound 4: middle estimate off by 1.0-fold (0.01 log units), on the low side; measured number inside the range.
By their numbers in this assay, from the lowest: compounds 3, 4 and 1 (each within the scatter of the next, the first and the last beyond it). At a limit, above all of these: compound 2.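

In this assay, the step of a 1.4-fold higher number from compound 3 to compound 4 (0.14 log units; within the scatter) stays within the scatter, so moving on this amide-type nitrogen from 1 hydrogen-bond donor and 1 acceptor to 2 of each, with the entering group also carrying 1 defined stereocentre, gives no clear change in the number. The step of a 1.5-fold lower number from compound 1 to compound 4 (0.19 log units; within the scatter) is also within the scatter, so compound 4 cannot be told apart from either compound 1 or compound 3, even though the step between those two compounds lies beyond it. Compound 2 stands at a limit and not a number, so an at least 1.7-fold lower number from compound 2 to compound 4 (0.24 log units; that floor lies within the scatter) is only a minimum and does not show a real separation: the limit of > 50000 nM in this assay, at which 1 of the 4 values shown sits.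

Still open, as far as these compounds go, is whether an amine, a carboxylic acid or a longer chain ending in hydroxyl on this nitrogen would move the number clearly beyond the scatter from compound 3. Also open is whether the opposite configuration at the stereocentre of 3-hydroxy-1-(hydroxymethyl)propyl would give a different number, since the only stereochemical pair shown, compounds 1 and 2, carries a different group.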